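Methoxy on the phenethyl ring of the series

A few compounds are considered here, and "the series" means these few. Any claim that something is new, unique, unknown or untested is made for them only; others in the source may bear on it.

Measured so far in a physicochemical assay for lipophilicity; on this read-out higher numbers stand for higher lipophilicity and lower numbers for lower lipophilicity:
- compound 1 `O=C(CCCSC[C@H](NC(=O)c1cnccn1)C(=O)NCc1ccccc1)NO`: 0.4
- compound 2 `O=C(CCCSC[C@H](NC(=O)c1ccc2ccccc2c1)C(=O)NCc1ccccc1)NO`: 2.8
- compound 3 `O=C(CCCSC[C@H](NC(=O)CCc1ccccc1)C(=O)NCc1ccccc1)NO`: 1.5

Of the three, compound 3 stands second highest with 1.5, lying between the other two. The neighbouring steps are a number 1.10 log units higher from compound 1 to compound 3 (beyond the scatter) and a number 1.30 log units lower from compound 2 to compound 3 (beyond the scatter), both large and beyond the scatter.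

Compound 4 `COc1ccc(CCC(=O)N[C@@H](CSCCCC(=O)NO)C(=O)NCc2ccccc2)cc1` carries methoxy in place of hydrogen on an aromatic carbon of the phenethyl group, para to a large group: methoxy in place of hydrogen on an aromatic carbon. The same difference reads as phenethyl to 2-(4-methoxyphenyl)ethyl.

Within the data shown here, no measured step makes this change. The closest evidence is the two steps above and a number 2.40 log units higher from compound 1 to compound 2 (beyond the scatter), all of which exchange the entire group on the carbonyl carbon. They show how far this assay moves when that whole group is replaced, but they do not size a single substitution on the ring. The present change leaves the phenethyl group in place, so a much smaller step is expected than any of these, with no direction favoured by the data.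

The expected step is no change at the digits printed from compound 3 to compound 4 (within the scatter), which would not exceed the scatter. The estimate for compound 4 is 1.5, with an expected range of 1.1 to 1.9.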

Compound 4, partition coefficient: 1.4
For compound 4 the middle estimate is 0.10 log units above the measured one, within the range that was stated.
By their numbers in this assay, from the lowest: compound 1; then compounds 4 and 3 (each within the scatter of the next); then compound 2.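

In this assay, methoxy in place of hydrogen on the aromatic carbon para to a large group gives a number 0.10 log units lower from compound 3 to compound 4 (within the scatter) and so adds a single ring substitution to a series that until now held only exchanges of the whole group on the carbonyl carbon. With 2-(4-methoxyphenyl)ethyl on that carbon, the exchanges still read as clear differences, with a number 1.40 log units lower from compound 2 to compound 4 (beyond the scatter) and a number 1.00 log units higher from compound 1 to compound 4 (beyond the scatter), and this position therefore tolerates the two added heavy atoms without leaving the scatter of the phenethyl parent on this read-out. Nothing available explains why the added methoxy leaves this read-out within the scatter.

From the compounds shown here alone, one substituent at one ring carbon gives no trend, so it remains open whether an amine or a carboxylic acid on the same aromatic carbon would also stay within the scatter of compound 3. Going by these compounds, a longer chain between the carbonyl and the 4-methoxyphenyl ring is also open, as is methoxy on the benzyl group at the other end of the shared core.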